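A Methyl on the Amine Nitrogen of Compound 2

The source may report more compounds than this note shows. Statements on the series, on what has been measured and on what is new or still open speak of the compounds shown alone.

Of the compounds shown here, two of a shared core have been measured in an assay on isolated protein for inhibition of DNA topoisomerase 1 (Homo sapiens), with a stated time of 15 min; a lower number here means a stronger inhibitor, a higher number a weaker inhibitor. Compound 1 `O=C(O)c1cn(Cc2ccc(-c3ccccc3)cc2)c2cc(NC[C@@H]3CCNC3)c(F)cc2c1=O` gives 104000 nM. Compound 2 `NC[C@@H]1CCN(c2cc3c(cc2F)c(=O)c(C(=O)O)cn3Cc2ccc(-c3ccccc3)cc2)C1` gives 15600 nM, the lowest of the two numbers shown; the single measured step, a 6.7-fold lower number from compound 1 to compound 2 (0.82 log units; beyond the scatter), places 3-(aminomethyl)pyrrolidin-1-yl in place of ((pyrrolidin-3-yl)methyl)amino on an aromatic carbon. Compound 3 `CNC[C@@H]1CCN(c2cc3c(cc2F)c(=O)c(C(=O)O)cn3Cc2ccc(-c3ccccc3)cc2)C1` differs from compound 2 by methyl in place of hydrogen on an amine nitrogen. For the measured compounds named here, no measured step bears on this change: the step already described alters how the pyrrolidin-1-yl group is joined to the core and says nothing about a methyl on an amine nitrogen. Going by the values given here, with no guiding step, the expectation in this assay is a change of no size beyond the scatter, written as a 1.0-fold lower number from compound 2 to compound 3 (0.02 log units; within the scatter). Compound 3 is therefore estimated at 15000 nM, with a range from 5000 nM to 45000 nM.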

Compound 3, half-maximal inhibitory concentration: 168000 nM
Beside the measured number, compound 3's estimate is 11-fold (1.05 log units) below it, outside the stated range (above it).
By their numbers in this assay, from the lowest: compound 2; then compounds 1 and 3 (each within the scatter of the next).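

On the amine nitrogen of the 3-(aminomethyl)pyrrolidin-1-yl group, the smallest possible addition is enough to change the result in this assay: methyl in place of hydrogen gives an 11-fold higher number from compound 2 to compound 3 (1.03 log units; beyond the scatter), a large step for one heavy atom. The further step, a 1.6-fold higher number from compound 1 to compound 3 (0.21 log units; within the scatter), shows that the addition cancels the advantage compound 2 held over compound 1, so that advantage depends on the unsubstituted amine nitrogen as well as on how the group is joined to the core. Nothing available explains why the methyl has this effect.

The compounds shown leave open whether the loss grows, levels off or reverses with an ethyl or an acetyl on this nitrogen. They also leave open whether a second methyl, giving a dimethylamino group, would go further.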